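The source may report more compounds than this note shows. Statements on the series, on what has been measured and on what is new or still open speak of the compounds shown alone.

Within the data shown here, in a functional assay on PC-3 cells (Homo sapiens) for inhibition, read by MTT assay, with a stated time of 48 h (on this read-out higher numbers stand for weaker inhibition and lower numbers for stronger inhibition), compound 1 (`COc1ccc(-c2coc3cc(OCCCBr)ccc3c2=O)cc1`) gives 62600 nM, the highest of the two numbers so far. Compound 2 (`COc1ccc(-c2coc3cc(OCCCCSC(=S)N4CCN(C(=O)OC(C)(C)C)CC4)ccc3c2=O)cc1`) gives 4610 nM, a lower number by more than the scatter. Compound 3 (`COc1ccc(-c2coc3cc(OCCCSC(=S)N4CCN(C)CC4)ccc3c2=O)cc1`) departs from compound 1 as follows: a group of 10 heavy atoms (6 carbon, 2 nitrogen, 2 sulfur; one six-membered non-aromatic ring with 2 hetero atoms) in place of one bromine atom, on a saturated chain carbon, three bonds along the chain from an oxygen on an aromatic ring. Among the measured compounds shown here, no measured step covers this change, so the expectation rests only on compound 2 at 4610 nM. A fall beyond the scatter is expected in this assay, and the estimated size is an 8.9-fold lower number from compound 1 to compound 3 (0.95 log units; beyond the scatter). The estimate for compound 3 is 7000 nM, with an expected range of 2000 nM to 25000 nM.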

Compound 3, half-maximal inhibitory concentration: 2210 nM
Compound 3: the middle estimate sits 3.2-fold (0.50 log units) above what was measured; the range from low to high includes it.
By their numbers in this assay, from the lowest: compound 3; then compound 2; then compound 1.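

In this assay, putting the group with the six-membered non-aromatic ring in place of bromo on this chain carbon gives a 28-fold lower number from compound 1 to compound 3 (1.45 log units; beyond the scatter) and is large. The chain stays as in compound 1, so a change at its end alone is enough for a fall of this size. Nothing measured here accounts for the size of this step.

From the compounds shown here alone, it remains open how much of the step belongs to the ring and how much to the sulfur atoms; a simple amine or a carboxylic acid in place of bromo would separate them. The effect of chain length alone also stays unresolved, as compound 2 and compound 3 differ in more than one place.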